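The compounds below may be only part of what the source reports. "The series", "measured", "known", "first", "only" and "open" are said of these compounds alone.

Measured compounds in an ADME assay on cells (Hepatocyte, Homo sapiens) for metabolic stability; a lower number here means slower removal, a higher number faster removal of the compound:
- compound 1 `Cn1ncc(-c2cc(Cl)c3c(=O)[nH]nc(CN)c3c2)c1-c1sc2ccccc2c1C#N` — 71 mL/min/kg
- compound 2 `Cn1ncc(-c2cc(C(F)F)c3c(=O)[nH]nc(CN)c3c2)c1-c1sc2ccccc2c1C#N` — 44 mL/min/kg
- compound 3 `CCOc1cc(-c2cnn(C)c2-c2sc3ccccc3c2C#N)cc2c(CN)n[nH]c(=O)c12` — < 18 mL/min/kg

The value recorded for compound 3 is a limit of this assay and not a number. Compound 3 therefore stands at the low end of the three, with only a bound known, as marked by the limit of < 18 mL/min/kg in this assay, at which 1 of the 3 values shown sits.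

Compound 4 `Cc1cc(-c2cnn(C)c2-c2sc3ccccc3c2C#N)cc2c(CN)n[nH]c(=O)c12` differs from compound 3 in one place: methyl in place of ethoxy on an aromatic carbon.

For the measured compounds named here, two measured steps bear on this change, both leading into the ethoxy compound: an at least 3.9-fold lower number from compound 1 to compound 3 (0.59 log units; beyond the scatter) and an at least 2.4-fold lower number from compound 2 to compound 3 (0.38 log units; beyond the scatter). In both, arriving at ethoxy lowered the number beyond the scatter. Leaving ethoxy for methyl is expected to reverse part of that, since methyl resembles chloro and difluoromethyl more than ethoxy in what is counted under the change. The step for compound 4 is therefore expected to be upward, estimated at an at least 2.2-fold higher number from compound 3 to compound 4 (0.34 log units; beyond the scatter), likely beyond the scatter. Compound 4 is expected to give 40 mL/min/kg, between 18 mL/min/kg and 80 mL/min/kg.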

Compound 4, clearance: 27 mL/min/kg
Compound 4: middle estimate off by 1.5-fold (0.17 log units), on the high side; the measured number falls inside the stated range.
By their numbers in this assay, from the lowest: compounds 4, 2 and 1 (each within the scatter of the next, the first and the last beyond it). At a limit, below all of these: compound 3.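

In this assay, methyl on this aromatic carbon gives the first measured step away from chloro that does not involve ethoxy, a 2.6-fold lower number from compound 1 to compound 4 (0.42 log units; beyond the scatter), so the lower number is not unique to ethoxy, while the comparison with difluoromethyl stays within the scatter, a 1.6-fold lower number from compound 2 to compound 4 (0.21 log units; within the scatter). The change from ethoxy to methyl reads an at least 1.5-fold higher number from compound 3 to compound 4 (0.17 log units; that floor lies within the scatter), which leaves undecided whether these two groups truly differ at this position. The value of compound 3 is a limit of this assay and not a number: the limit of < 18 mL/min/kg in this assay, at which 1 of the 4 values shown sits.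

As far as these compounds go, whether methoxy, a longer ether chain such as propoxy, or an amine on this aromatic carbon would fall with compound 3 or with compound 4 remains open. From the compounds shown here alone, the actual clearance of compound 3 also remains open.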